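The source may report more compounds than this note shows. Statements on the series, on what has been measured and on what is new or still open speak of the compounds shown alone.

Among the compounds with values here, compound 2 `C=CCOC(=O)Nc1ccc([Se]C#N)cc1` stands with the higher of the two numbers so far recorded in a functional assay on CCRF-CEM cells (Homo sapiens) for cytotoxicity, read by MTT assay, with a stated time of 72 h (on this read-out higher numbers stand for weaker inhibition of growth and lower numbers for stronger inhibition of growth), and its nearest neighbour, compound 1 `CCCCOC(=O)Nc1ccc([Se]C#N)cc1`, gives 6500 nM. In this assay compound 2 gives 9200 nM. Within the data shown here, the one step recorded, a 1.4-fold higher number from compound 1 to compound 2 (0.15 log units; within the scatter), altered the chain on a saturated chain carbon bound to an oxygen next to a carbonyl group. Compound 3 `CCOC(=O)Nc1ccc([Se]C#N)cc1` differs from compound 2 by methyl in place of vinyl on a saturated chain carbon bound to an oxygen next to a carbonyl group, a change of comparable size at the same place. Because a 1.4-fold higher number from compound 1 to compound 2 (0.15 log units; within the scatter) stayed within the scatter, a step of a 1.2-fold lower number from compound 2 to compound 3 (0.09 log units; within the scatter) is expected in this assay. Compound 3 is therefore estimated at 7500 nM, within 3500 nM to 16000 nM.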

Compound 3, concentration for 50% growth inhibition: 9800 nM
The estimate for compound 3 lay 1.3-fold (0.12 log units) below the measured number; the range from low to high includes it.
By their numbers in this assay, from the lowest: compounds 1, 2 and 3 (each within the scatter of the next).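

In this assay, methyl in place of vinyl at this place, a 1.1-fold higher number from compound 2 to compound 3 (0.03 log units; within the scatter), shows that the double bond outside aromatic rings can be lost without a step beyond the scatter. Hydrogen in place of ethyl on a saturated chain carbon, two bonds along the chain from an oxygen next to a carbonyl group, a 1.5-fold higher number from compound 1 to compound 3 (0.18 log units; within the scatter), also stays within the scatter, so this read-out does not separate these three chains. No evidence is available to explain the small size of these steps. The compounds shown leave open whether a longer chain, an amine or a carboxylic acid at this place would give a step beyond the scatter.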